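The source may hold more compounds than are shown below. What is called first, only, known or untested is meant among the compounds shown, and "the series" means these compounds.

For the measured compounds named here, in a functional assay on MT4 cells (Homo sapiens) for antiproliferative activity (on this read-out lower numbers stand for higher toxicity in this test and higher numbers for lower toxicity in this test), compound 1 `Cc1cn(C2OC(CO[Si](C)(C)C(C)(C)C)C3(OS(=O)(=O)C=C3N)C2O[Si](C)(C)C(C)(C)C)c(=O)n(CCCNC(=O)[C@@H]2CCCN2C(=O)[C@@H](N)C(C)C)c1=O` gives 11000 nM and compound 2 `Cc1cn(C2OC(CO[Si](C)(C)C(C)(C)C)C3(OS(=O)(=O)C=C3N)C2O[Si](C)(C)C(C)(C)C)c(=O)n(CCCNC(=O)[C@H](C)NC(=O)[C@@H](N)C(C)C)c1=O` gives 22000 nM, so compound 2 stands within the scatter of the only other number measured. Compound 3 `Cc1cn(C2OC(CO[Si](C)(C)C(C)(C)C)C3(OS(=O)(=O)C=C3N)C2O[Si](C)(C)C(C)(C)C)c(=O)n(CCCNC(=O)[C@@H](N)C(C)C)c1=O` carries 1-amino-2-methylpropyl in place of 1-(((1-amino-2-methylpropyl)carbonyl)amino)ethyl on a carbonyl carbon. Going by the values given here, only one measured step bears on this change, a 2.0-fold higher number from compound 1 to compound 2 (0.30 log units; within the scatter), and it altered the same side chain without leaving the scatter. It is a different exchange, however, so the evidence is thin. No step beyond the scatter is therefore expected in this assay. The estimated change is a 1.4-fold lower number from compound 2 to compound 3 (0.14 log units; within the scatter). For compound 3 the expected value is 16000 nM, within an estimated range of 6000 nM to 40000 nM.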

Compound 3, half-maximal cytotoxic concentration: 8200 nM
Estimate against measurement, compound 3: 2.0-fold (0.29 log units) above, and the stated range covers the measured number.
By their numbers in this assay, from the lowest: compounds 3, 1 and 2 (each within the scatter of the next, the first and the last beyond it).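

In this assay the exchange of 1-(((1-amino-2-methylpropyl)carbonyl)amino)ethyl for 1-amino-2-methylpropyl on this carbonyl carbon gives a 2.7-fold lower number from compound 2 to compound 3 (0.43 log units; beyond the scatter) as a modest step, the first at this position to pass the scatter. Replacing 1-((1-amino-2-methylpropyl)carbonyl)pyrrolidin-2-yl with the same group gives a 1.3-fold lower number from compound 1 to compound 3 (0.13 log units; within the scatter) and so does not separate those two side chains. Nothing available explains the difference between the two steps. Going by these compounds, what remains open is whether a carboxylic acid or a longer alkyl chain at this carbonyl carbon would move the number beyond the scatter.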